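A smaller aromatic ring at the double-bonded carbon

A few compounds are considered here, and "the series" means these few. Any claim that something is new, unique, unknown or untested is made for them only; others in the source may bear on it.

Compound 1 `CCCCC/C=C/C=C/C=N/Nc1nc(N)c2ncn([C@@H]3O[C@H](CO)[C@@H](O)[C@H]3O)c2n1`: 2 nM
Compound 2 `Nc1nc(N/N=C/c2ccc(N3CCCC3)cc2)nc2c1ncn2[C@@H]1O[C@H](CO)[C@@H](O)[C@H]1O`: 5.1 nM

In an assay on CHO-K1 cells for displacement of a labelled ligand from adenosine receptor A1 (Homo sapiens), read by scintillation counting, with a stated time of 60 min (on this read-out lower numbers stand for stronger inhibition and higher numbers for weaker inhibition), compound 1 gives 2 nM and compound 2 gives 5.1 nM. Compound 2 thus stands at the higher of the two numbers, separated from compound 1 by a 2.6-fold higher number from compound 1 to compound 2 (0.41 log units; beyond the scatter), a modest step.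

Compound 3 `Nc1nc(N/N=C/c2ccc[nH]2)nc2c1ncn2[C@@H]1O[C@H](CO)[C@@H](O)[C@H]1O` is the next variation at the same place. Its change is 1H-pyrrol-2-yl in place of 4-(pyrrolidin-1-yl)phenyl on a carbon with a double bond to nitrogen. Within the data shown here, the only measured step, a 2.6-fold higher number from compound 1 to compound 2 (0.41 log units; beyond the scatter), also swapped the group on that carbon with a double bond to nitrogen and moved the number modestly, so the position tolerates quite different groups without large shifts. Among the measured compounds shown here, no measured pair covers a small aromatic ring that carries a hydrogen-bond donor, so the direction is uncertain. A modest weakening is expected, with a 2.9-fold higher number from compound 2 to compound 3 (0.47 log units; beyond the scatter). Compound 3 is therefore estimated at 15 nM, with a range from 4 nM to 60 nM.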

Compound 3, inhibition constant: 8 nM
Beside the measured number, compound 3's estimate is 1.9-fold (0.27 log units) above it, and the stated range covers the measured number.
By their numbers in this assay, from the lowest: compound 1; then compounds 2 and 3 (each within the scatter of the next).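

In this assay, the exchange of 4-(pyrrolidin-1-yl)phenyl for 1H-pyrrol-2-yl gives a 1.6-fold higher number from compound 2 to compound 3 (0.20 log units; within the scatter) on this carbon with a double bond to nitrogen, so the two rings cannot be told apart here, even though the entering group has fewer heavy atoms and adds a hydrogen-bond donor. Set against the ring-free group of 9 carbon atoms, the same small ring gives a 4.0-fold higher number from compound 1 to compound 3 (0.60 log units; beyond the scatter) and leaves compound 1 with the lowest number of the three. Nothing available here explains these results.

On these data alone, it remains open how a plain phenyl ring, without the pyrrolidine, would behave on this carbon. As far as these compounds go, the effect of a shorter chain, an amine or a carboxylic acid at this place is also open.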